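This account rests on a few compounds, and the source may have more. Where it says the series, first, only, none or still open, it means among the compounds named here.

Measured so far:
- compound 1 `CCOC(=O)C1=C(S[C@@H]2CN[C@H](C(=O)Nc3cccc(C(=O)OCC)c3)C2)[C@H](C)[C@@H]2[C@@H]([C@@H](C)OC(=O)CC)C(=O)N12`: > 95%
- compound 2 `COC(=O)OCOC(=O)C1=C(S[C@@H]2CN[C@H](C(=O)Nc3cccc(C(=O)OCOC(=O)OC)c3)C2)[C@H](C)[C@@H]2[C@@H]([C@@H](C)O)C(=O)N12`: > 95%

Two compounds have been run in a physicochemical assay for metabolic stability, read by LC-MS, in phosphate buffer, with a stated time of 3 h, at pH 7.4, tested at 50 uM; on this read-out higher numbers stand for a more stable compound and lower numbers for a less stable compound. Compound 1 returned > 95%, which is a limit of the assay rather than a number. Compound 2 likewise returned > 95%, again a limit rather than a measured number. Compound 2 therefore stands at the top of what this assay reports, as does compound 1 (the limit of > 95% in this assay, at which 2 of the 2 values shown sit). Going by the values given here, no pair of measured compounds differing in a single place has been compared, so nothing is yet known about how one change moves this read-out.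

Compound 3 `COC(=O)OCOC(=O)C1=C(S[C@@H]2CN[C@H](C(=O)Nc3cccc(C(=O)O)c3)C2)[C@H](C)[C@@H]2[C@@H]([C@@H](C)O)C(=O)N12` has not been measured. It differs from compound 2 by hydrogen in place of ((methoxycarbonyl)oxy)methyl on an oxygen next to a carbonyl group. With compound 2 sitting at the limit, compound 3 is expected to stay close to it, and the expected step is a number no higher from compound 2 to compound 3 (the limit leaves the size open), none beyond the scatter. For compound 3 in this assay the estimate is 95%, ranging from 85% to 100%.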

Compound 3, percent of the compound remaining: > 95%
Compound 3 ended at the assay's limit; the forecaster's own chance of this, stated with the estimate: 70%; the middle value lies on the limit itself.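

No step can be read from compound 2 to compound 3 in this assay, because both ended at the same limit of the assay: the limit of > 95% in this assay, at which 3 of the 3 values shown sit.

The compounds shown leave open whether hydrogen in place of ((methoxycarbonyl)oxy)methyl changes this read-out at all, and by how much.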